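Amide substituent change from compound 1 to compound 4

The source may hold more compounds than are shown below. What is called first, only, known or untested is meant among the compounds shown, and "the series" means these compounds.

Measured so far:
compound 1 `CNC(=O)c1cc(C(=O)N[C@H]2[C@@H]3C[C@H](O)C[C@@H]32)cc2c1OC[C@@]2(C)c1ccccc1`: 539 ug/mL
compound 2 `CNC(=O)c1cc(C(=O)N[C@H]2[C@@H]3COC[C@@H]32)cc2c1O[C@H](CF)[C@H]2c1ccccc1`: 80 ug/mL
compound 3 `CNC(=O)c1cc(C(=O)N[C@H]2[C@@H]3COC[C@@H]32)cc2c1OC[C@@]2(C)c1ccccc1`: 80 ug/mL

Compound 4 `CNC(=O)c1cc(C(=O)N[C@H]2C[C@@H]2C)cc2c1OC[C@@]2(C)c1ccccc1` awaits measurement. In a physicochemical assay for solubility, read by HPLC, in simulated intestinal fluid, with a stated time of 16 h, at pH 6.5, tested at 2.5 mg/mL (a higher number here means a more soluble compound, a lower number a less soluble compound), compound 1 stands highest of the three, at 539 ug/mL. Going to compound 4, the change is a group of 4 heavy atoms (4 carbon; one three-membered non-aromatic ring of carbon only) in place of a group of 7 heavy atoms (6 carbon, 1 oxygen; one three-membered non-aromatic ring of carbon only, one five-membered non-aromatic ring of carbon only), on an amide-type nitrogen; the entering group is 2-methylcyclopropyl. One measured step removes the same group from the same nitrogen: a 6.7-fold lower number from compound 1 to compound 3 (0.83 log units; beyond the scatter), modest but beyond the scatter. For the measured compounds named here, with only that step as a guide, a fall of similar order is expected in this assay, though the entering group differs and the transfer is uncertain. The estimated step is a 5.4-fold lower number from compound 1 to compound 4 (0.73 log units; beyond the scatter). For compound 4 the expected value is 100 ug/mL, with an estimated range of 30 ug/mL to 300 ug/mL.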

Compound 4, solubility: 88 ug/mL
Estimate against measurement, compound 4: 1.1-fold (0.06 log units) above; measured number inside the range.
By their numbers in this assay, from the lowest: compounds 2, 3 and 4 (each within the scatter of the next); then compound 1.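

In this assay, the replacement of the group of compound 1 with 2-methylcyclopropyl on the amide-type nitrogen gives a 6.1-fold lower number from compound 1 to compound 4 (0.79 log units; beyond the scatter). The fall therefore does not need the ring oxygen carried by the group of compound 3, since a group of carbon only gives a 1.1-fold higher number from compound 3 to compound 4 (0.04 log units; within the scatter), so these two groups cannot be told apart here. No available measurement accounts for the fall.

Still open, going by these compounds, is whether an amine or a carboxylic acid on this nitrogen's substituent would match compound 1 at 539 ug/mL. On these data alone, the shift of 2-methylcyclopropyl onto other cores also remains untested.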